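Trifluoromethyl for fluoro on a pair of inactive diamides

The source may report more compounds than this note shows. Statements on the series, on what has been measured and on what is new or still open speak of the compounds shown alone.

Compound 1 `O=C(Nc1cccc(NC(=O)c2cccc(Cl)c2)c1)c1cccc(F)c1` carries two amide-linked aryl groups on the shared core. In an in vitro functional assay on HEK293-A cells for antagonist activity at metabotropic glutamate receptor 5 (Rattus norvegicus), read by calcium flux (a higher number here means a weaker inhibitor, a lower number a stronger inhibitor), compound 1 gives > 30000 nM, which is a limit of the assay and not a number. Compound 2 `O=C(Nc1cccc(NC(=O)c2cccc(Cl)c2)c1)c1ccc(F)cc1` differs from compound 1 only in the placement of the fluorine. In this assay compound 2 gives > 30000 nM, again a limit. Going by the values given here, the single measured step, a step that the two limits leave unreadable from compound 1 to compound 2, is therefore of unreadable size, since both values sit at the limit of > 30000 nM in this assay, at which 2 of the 2 values shown sit. Compound 1 thus stands at a limit only; no numbered value exists anywhere in this small set.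

Compound 3 `O=C(Nc1cccc(NC(=O)c2cccc(C(F)(F)F)c2)c1)c1cccc(Cl)c1` differs from compound 1 by trifluoromethyl in place of fluoro on an aromatic carbon. Among the compounds with values here, no measured step bears on this change, and the one step that has been measured reads as nothing beyond its two limits, so neither a size nor a direction can be taken from the data. The expectation for compound 3 rests solely on the fact that both measured compounds sit at the limit. Compound 3 is therefore expected to remain at or near that limit in this assay, estimated at 40000 nM with a range of 10000 nM to 150000 nM. The expected step that the limit leaves unreadable from compound 1 to compound 3 is accordingly estimated to be unreadable rather than a change beyond the scatter.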

Compound 3, half-maximal inhibitory concentration: > 30000 nM
Compound 3 ended at the assay's limit; the forecaster's own chance of this, stated with the estimate: 80%; the middle value is on the limit's open side.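

The step between compound 1 and compound 3 cannot be read, because each compound stands at a limit of the assay and not at a number: the limit of > 30000 nM in this assay, at which 3 of the 3 values shown sit. The compounds shown leave open whether any aryl change on the shared core gives a numbered value in this assay, and what size or direction the trifluoromethyl change has.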